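Chloro to Bromo on the Aryl Ring of Compound 2

The compounds below may be only part of what the source reports. "The series", "measured", "known", "first", "only" and "open" are said of these compounds alone.

Measured in a functional assay on DU-145 cells (Homo sapiens) for cytotoxicity, read by trypan blue exclusion, with a stated time of 96 h; a lower number here means a stronger inhibitor, a higher number a weaker inhibitor:
- Compound 1 `COc1cc(OC)c(/C=C/S(=O)(=O)Cc2ccc(OC)c(NC(F)(F)C(=O)O)c2)c(OC)c1`: 150 nM
- Compound 2 `COc1cc(OC)c(/C=C/S(=O)(=O)Cc2ccc(OC)c(NC(C(=O)O)c3ccc(Cl)cc3)c2)c(OC)c1`: 400 nM

Of these two compounds, compound 2 holds the higher number at 400 nM, making it the weaker inhibitor. The gap between them is a 2.7-fold higher number from compound 1 to compound 2 (0.43 log units; beyond the scatter). The next compound, compound 3 `COc1cc(OC)c(/C=C/S(=O)(=O)Cc2ccc(OC)c(NC(C(=O)O)c3ccc(Br)cc3)c2)c(OC)c1`, departs from compound 2 at a single place: bromo in place of chloro on an aromatic carbon. The rest of the molecule is unchanged.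

Among the compounds with values here, only one measured step is available, and it bears on this change only indirectly. That step, a 2.7-fold higher number from compound 1 to compound 2 (0.43 log units; beyond the scatter), is modest and exchanges the whole group on the nitrogen, whereas here that group keeps its carboxy and its aromatic ring. Within the data shown here, no measured pair tests chloro against bromo. In this assay, no step beyond the scatter is therefore expected, and no direction is favoured. The expected change is no change at the digits printed from compound 2 to compound 3 (within the scatter). For compound 3 the estimated value is 400 nM, with an expected range from 200 nM to 800 nM.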

Compound 3, half-maximal inhibitory concentration: 300 nM
Estimate against measurement, compound 3: 1.3-fold (0.12 log units) above; measured number inside the range.
By their numbers in this assay, from the lowest: compounds 1, 3 and 2 (each within the scatter of the next, the first and the last beyond it).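

In this assay, the change from chloro to bromo on an aromatic carbon para to a large group gives a 1.3-fold lower number from compound 2 to compound 3 (0.12 log units; within the scatter) and so does not separate these two halogens at this position. The earlier compounds shown here showed only an exchange of the whole group on the nitrogen, where the chloro compound gave a 2.7-fold higher number from compound 1 to compound 2 (0.43 log units; beyond the scatter), and the bromo counterpart now gives a 2.0-fold higher number from compound 1 to compound 3 (0.30 log units; within the scatter) for the same kind of exchange. One comparison is printed as beyond the scatter and the other as within it, but that difference carries little weight, as compound 2 and compound 3 themselves lie within the scatter of each other. No measurement among the data shown accounts for these numbers.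

Left open is whether a group other than a halogen at this place, such as a nitrile, an amine or a carboxylic acid, would also stay within the scatter of compound 2 in this assay. The compounds shown also leave open how the unsubstituted phenyl ring would compare, and whether the bromo and chloro compounds would stay this close on cells other than DU-145.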